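The source may hold more compounds than are shown below. What is called first, only, known or untested is meant among the compounds shown, and "the series" means these compounds.

Two members of the series have been measured so far. Compound 1 `COc1ccc2c(c1)CCc1ccc(OC)c(c1)Oc1ccc(cc1)-c1nc(N)sc1-c1cccc(c1)O2` and compound 2 `Nc1nc2c(s1)-c1cccc(c1)Oc1ccc(O)cc1CCc1ccc(O)c(c1)Oc1ccc-2cc1` share the same core and were both tested in a functional assay on K562/A02 cells (Homo sapiens) for cytotoxicity, read by MTT assay, with a stated time of 48 h, tested at 10 uM; a higher number here means more inhibition at the concentration tested (going by the name of the read-out), a lower number less inhibition. Compound 1 gives 26.8%, the higher of the two numbers available. Compound 2 gives 10.1%, which lies beyond the usual scatter below compound 1. For the measured compounds named here, the two measured compounds differ in more than one place, so no single-change step has been measured.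

Compound 3 `COc1ccc2c(c1)CCc1ccc(OC)c(c1)Oc1ccc(cc1)-c1nc(NN)sc1-c1cccc(c1)O2` is still to be measured in this assay. It differs from compound 1 by amino in place of hydrogen on a nitrogen on an aromatic ring. Nothing in the two measured compounds speaks to this change, so the expectation rests on compound 1 alone. The expected step is small, in no settled direction, and may not exceed the scatter: a number 0.2 percentage points higher from compound 1 to compound 3 (within the scatter). Compound 3 is accordingly estimated at 27% in this assay, within a range of 12% to 45%.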

Compound 3, a percentage reported as inhibition, at one concentration (the size of the read-out at that concentration, not a potency): 18.8%
Compound 3: the middle estimate sits 8.2 percentage points above what was measured; the measured number falls inside the stated range.
By their numbers in this assay, from the lowest: compounds 2, 3 and 1 (each within the scatter of the next, the first and the last beyond it).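

In this assay the nitrogen on the aromatic ring now has its first single-change step: amino in place of hydrogen gives a number 8 percentage points lower from compound 1 to compound 3 (within the scatter), so this change cannot be told apart from no change at all. At this one concentration, the position therefore accepts an amino group without a separable shift in the read-out, which is a size at that concentration and not a potency. Nothing measured here bears on the reason for this result.

As far as these compounds go, whether a larger group on this nitrogen, such as acetyl or a longer alkyl chain, would move the number beyond the scatter remains open. Also open, from the compounds shown here alone, is whether the same amino change would behave alike on the hydroxy-bearing core of compound 2.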